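A few compounds are considered here, and "the series" means these few. Any claim that something is new, unique, unknown or untested is made for them only; others in the source may bear on it.

Compound 1 `CN(C)c1cccc(OCCCn2cnc(-c3ccccc3)c2)c1NC(=O)NC1CCCCC1`: 73 nM
Compound 2 `CCCCCCNc1c(OCCCn2cnc(-c3ccccc3)c2)cccc1N(C)C`: 11000 nM

Within the data shown here, in an assay for inhibition of acyl-CoA:cholesterol acyltransferase (Oryctolagus cuniculus), using microsomes (a lower number here means a stronger inhibitor, a higher number a weaker inhibitor), compound 1 gives 73 nM, while compound 2 gives 11000 nM, the higher of the two numbers; the only neighbour is compound 1, and the step of a 150-fold higher number from compound 1 to compound 2 (2.18 log units; beyond the scatter) is large. Compound 3 `CCCCCN(C)C(=O)Nc1c(OCCCn2cnc(-c3ccccc3)c2)cccc1N(C)C` is the next step from compound 2: methyl(pentyl)carbamoyl in place of hexyl on a nitrogen on an aromatic ring. This brings a carbamoyl group back onto that nitrogen, which is the kind of group that was lost in the step from compound 1 to compound 2, although here the second nitrogen carries a methyl and a pentyl chain rather than a cyclohexyl and a hydrogen. The step that bears on this change is therefore a 150-fold higher number from compound 1 to compound 2 (2.18 log units; beyond the scatter), and compound 3 is expected to move a good part of the way back, giving a 44-fold lower number from compound 2 to compound 3 (1.64 log units; beyond the scatter) in this assay. The estimate for compound 3 is 250 nM, in the range 40 nM to 1600 nM.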

Compound 3, half-maximal inhibitory concentration: 550 nM
The estimate for compound 3 lay 2.2-fold (0.34 log units) below the measured number; measured number inside the range.
By their numbers in this assay, from the lowest: compound 1; then compound 3; then compound 2.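

In this assay, a carbamoyl group on this nitrogen restores much of what was lost with hexyl, giving a 20-fold lower number from compound 2 to compound 3 (1.30 log units; beyond the scatter), even though its far nitrogen now carries a methyl and a pentyl chain instead of the cyclohexylamino group. What sits on the carbonyl carbon still counts, though on a smaller scale in these three compounds: a 7.5-fold higher number from compound 1 to compound 3 (0.88 log units; beyond the scatter) is modest, whereas the step between hexyl and the carbamoyl group is large. No supporting measurement explains the size of either step.

The exchange on the carbonyl carbon changes two things at once, so the compounds shown do not tell whether the added methyl or the open chain in place of the ring accounts for the weaker number. A pentylamino group or a methyl(cyclohexyl)amino group on the same carbonyl carbon would separate these two changes.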